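A few compounds are considered here, and "the series" means these few. Any claim that something is new, unique, unknown or untested is made for them only; others in the source may bear on it.

Working notes on the series. Three compounds sharing one core carry numbers in a functional assay on SW-620 cells (Homo sapiens) for cytotoxicity, read by sulforhodamine B assay, with a stated time of 48 h; on this read-out lower numbers stand for stronger inhibition of growth and higher numbers for weaker inhibition of growth. Compound 1 `ClCc1ccccc1Cn1cnc2c(Cl)nc(Cl)nc21` gives 350 nM. Compound 2 `ClCc1ccccc1Cn1cnc2c(Cl)ncnc21` gives 5010 nM, the highest of the three numbers. Compound 3 `ClCc1cccc(Cn2cnc3c(Cl)ncnc32)c1` gives 4360 nM, and the numbers of compound 2 and compound 3 lie within the scatter of each other, so nothing separates them. Among the measured compounds shown here, the only single-point step among the measured compounds is a 14-fold higher number from compound 1 to compound 2 (1.16 log units; beyond the scatter); loss of the chloro group left a much higher number.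

Compound 4 `Nc1nc(Cl)c2ncn(Cc3ccccc3CCl)c2n1` is not yet measured. It differs from compound 2 in one place: amino in place of hydrogen on an aromatic carbon. The entering amino occupies the place that carries chloro in compound 1 and hydrogen in compound 2, so the step from compound 1 to compound 2 is the one that bears on it: it was large, and it shows that a group at this place can move the number strongly. For the measured compounds named here, an amino group has no measured counterpart, so its direction is not fixed by the data; a step beyond the scatter toward a lower number is the working expectation, written as a 2.8-fold lower number from compound 2 to compound 4 (0.44 log units; beyond the scatter). The estimate for compound 4 in this assay is 1800 nM, with a range from 450 nM to 7000 nM.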

Compound 4, concentration for total growth inhibition: 11800 nM
Beside the measured number, compound 4's estimate is 6.6-fold (0.82 log units) below it; measured number outside the range, above it.
By their numbers in this assay, from the lowest: compound 1; then compounds 3 and 2 (each within the scatter of the next); then compound 4.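

In this assay, amino in place of hydrogen on the aromatic carbon between two ring nitrogen atoms gives a 2.4-fold higher number from compound 2 to compound 4 (0.37 log units; beyond the scatter), so placing a group here does not in itself bring a lower number. Amino in place of chloro gives a 34-fold higher number from compound 1 to compound 4 (1.53 log units; beyond the scatter), a larger change than the earlier 14-fold higher number from compound 1 to compound 2 (1.16 log units; beyond the scatter), and across compound 1, compound 2 and compound 4 the number rises in the order chloro, hydrogen, amino, with each step beyond the scatter. The low number of compound 1 therefore goes with chloro at this place among the three groups shown, and no information bears on why these groups fall in this order.

The compounds shown leave open whether the low number is particular to chloro or is shared by other groups at this place, such as bromo, fluoro, methyl or methoxy. They also leave open whether the same order of chloro, hydrogen and amino holds when the chloromethyl group stands as it does in compound 3.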